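Weaker antiproliferative numbers with ester or acid side chains

This account rests on a few compounds, and the source may have more. Where it says the series, first, only, none or still open, it means among the compounds named here.

Measured so far:
compound 1 `CCn1c(C(=O)NCCN(C)C)ccc1C(CC)(CC)c1ccc(OCCC(O)(CC)CC)c(C)c1` — 990 nM
compound 2 `CCOC(=O)C(CC(=O)OC)NC(=O)c1ccc(C(CC)(CC)c2ccc(OCCC(O)(CC)CC)c(C)c2)n1CC` — 4280 nM
compound 3 `CCn1c(C(=O)N(C)CC(=O)O)ccc1C(CC)(CC)c1ccc(OCCC(O)(CC)CC)c(C)c1` — 2150 nM

In an ADME assay on L02 cells (Homo sapiens) for antiproliferative activity, read by MTT assay, with a stated time of 48 h (a higher number here means a weaker inhibitor, a lower number a stronger inhibitor), compound 1 gives the lowest number of the three. Compound 3 is nearest to it, a 2.2-fold higher number from compound 1 to compound 3 (0.34 log units; beyond the scatter), and compound 2 is furthest, a 4.3-fold higher number from compound 1 to compound 2 (0.64 log units; beyond the scatter). Between the two amide variants the gap is small, a 2.0-fold lower number from compound 2 to compound 3 (0.30 log units; within the scatter).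

Compound 4 `CCn1c(C(=O)NC(CC(=O)O)C(=O)OC)ccc1C(CC)(CC)c1ccc(OCCC(O)(CC)CC)c(C)c1` is not yet measured. Against compound 1 the change is a group of 9 heavy atoms (5 carbon, 4 oxygen; no ring) in place of a group of 5 heavy atoms (4 carbon, 1 nitrogen; no ring), on an amide-type nitrogen.

Going by the values given here, two measured steps bear on this. Both replacements of the 2-(dimethylamino)ethyl group on the amide nitrogen of compound 1 by a carboxylate- or ester-bearing chain moved the number up: a 4.3-fold higher number from compound 1 to compound 2 (0.64 log units; beyond the scatter) and a 2.2-fold higher number from compound 1 to compound 3 (0.34 log units; beyond the scatter). The entering group of compound 4 carries both a free acid and a methyl ester, so it sits between compound 2 and compound 3 in kind, and those two differ only within the scatter. A modest rise beyond the scatter is therefore expected, a 3.0-fold higher number from compound 1 to compound 4 (0.48 log units; beyond the scatter).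

For compound 4 the number in this assay is estimated at 3000 nM, with a likely range of 1500 nM to 6500 nM.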

Compound 4, half-maximal inhibitory concentration: 7590 nM
The estimate for compound 4 lay 2.5-fold (0.40 log units) below the measured number; the whole stated range lies below it.
By their numbers in this assay, from the lowest: compound 1; then compounds 3, 2 and 4 (each within the scatter of the next, the first and the last beyond it).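

In this assay, the chain that replaces 2-(dimethylamino)ethyl on the amide-type nitrogen in compound 4 gives a 7.7-fold higher number from compound 1 to compound 4 (0.88 log units; beyond the scatter), and compound 1 remains the lowest of the four, with its steps to all the others beyond the scatter. What is new is that the chains without an amine no longer read as one group: a 3.5-fold higher number from compound 3 to compound 4 (0.55 log units; beyond the scatter), although both chains carry a free carboxylic acid, while a 1.8-fold higher number from compound 2 to compound 4 (0.25 log units; within the scatter), which places the acid-bearing chain of compound 4 level with the ester-only chain of compound 2, so the presence of a free acid does not by itself fix the number in this series. Nothing at hand accounts for these differences.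

Open, from the compounds shown here alone, is whether the low number of compound 1 goes with the dimethylamino group or with the chain that carries it, which a plain ethyl or a 3-(dimethylamino)propyl group on the same nitrogen would separate. Also open, going by these compounds, is what the methyl on the amide nitrogen of compound 3 contributes, which a carboxymethyl group that keeps the amide hydrogen would show.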